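The source may report more compounds than this note shows. Statements on the series, on what has been measured and on what is new or still open speak of the compounds shown alone.

Compound 1 `CCn1c(/C=C2\SC(=O)N(CC(=O)N3CCCCC3)C2=O)nc2ccccc21`: > 50000 nM
Compound 2 `CCn1c(/C=C2\SC(=O)N(CC(=O)Nc3cc(C(C)(C)C)on3)C2=O)nc2ccccc21`: > 50000 nM

In a functional assay on PC-3 cells (Homo sapiens) for inhibition, read by MTT assay, with a stated time of 48 h (on this read-out higher numbers stand for weaker inhibition and lower numbers for stronger inhibition), compound 1 gives > 50000 nM, which is a limit of the assay and not a number. Compound 2 gives > 50000 nM, which is also a limit. The whole record so far is the limit of > 50000 nM in this assay, at which 2 of the 2 values shown sit, so compound 1 offers no exact value to start from.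

Compound 3 `CC(C)n1c(/C=C2\SC(=O)N(CC(=O)N3CCCCC3)C2=O)nc2ccccc21` keeps the core of compound 1 and differs in one place: methyl in place of hydrogen on a saturated chain carbon bound to an aromatic nitrogen and a saturated chain carbon. This is methyl in place of hydrogen on a saturated chain carbon bound to an aromatic nitrogen and a saturated chain carbon, so ethyl becomes isopropyl.

Going by the values given here, the only measured step is a step that the two limits leave unreadable from compound 1 to compound 2. It concerns another place in the structure, and it gives no size to carry over. Among the compounds with values here, no measured step touches the ethyl group. The expectation therefore rests on compound 1 at > 50000 nM, and a result at the limit is the likeliest outcome in this assay. The expected step is a step that the limit leaves unreadable from compound 1 to compound 3, with none expected beyond the scatter. The estimated value for compound 3 is 60000 nM, with an expected range from 30000 nM to 120000 nM.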

Compound 3, half-maximal inhibitory concentration: > 50000 nM
Compound 3: no number, only a limit; the forecaster's own chance of this, stated with the estimate: 85%; the middle value does not contradict the limit.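

In this assay compound 3 gives > 50000 nM and this is a limit of the assay, not a number. Going by these compounds alone, no step from compound 1 to compound 3 can be read, and the change from ethyl to isopropyl gets no size. The record stands as follows: the limit of > 50000 nM in this assay, at which 3 of the 3 values shown sit. The compounds shown leave open how far each lies beyond that limit, and whether ethyl and isopropyl differ at all in this assay.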